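Chlorine for bromine on the aryl ester in compound 4

This account rests on a few compounds, and the source may have more. Where it says the series, first, only, none or still open, it means among the compounds named here.

Of the compounds shown here, three sharing one core have been tested in an ADME assay on cells (T-cell, Mus musculus, strain BALB/c) for cytotoxicity, read by MTT assay, with a stated time of 48 h; on this read-out lower numbers stand for higher toxicity in this test and higher numbers for lower toxicity in this test. Compound 1 `COC(=O)c1cccc(C)c1OC(=O)COc1cc(O)c2c(=O)cc(-c3ccccc3)oc2c1` gives 299000 nM, compound 2 `COC(=O)c1ccc(Cl)cc1OC(=O)COc1cc(O)c2c(=O)cc(-c3ccccc3)oc2c1` gives 265000 nM, and compound 3 `COC(=O)c1c(Br)cccc1OC(=O)COc1cc(O)c2c(=O)cc(-c3ccccc3)oc2c1` gives 388000 nM. Compound 3 has the highest of the three numbers, but the gap to its nearest neighbour is a 1.3-fold higher number from compound 1 to compound 3 (0.11 log units; within the scatter) and the gap to the furthest is a 1.5-fold higher number from compound 2 to compound 3 (0.17 log units; within the scatter), so all three sit within the ordinary scatter of the test, and none can be called less or more toxic than another.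

Compound 4 `COC(=O)c1cccc(Cl)c1OC(=O)COc1cc(O)c2c(=O)cc(-c3ccccc3)oc2c1` is the next step. Its change from compound 3 is a group of 11 heavy atoms (8 carbon, 2 oxygen, 1 chlorine; one six-membered aromatic ring of carbon only) in place of a group of 11 heavy atoms (8 carbon, 2 oxygen, 1 bromine; one six-membered aromatic ring of carbon only), on an oxygen next to a carbonyl group

The steps measured so far that swap one such aryl group for another are all of this kind: a 1.1-fold lower number from compound 1 to compound 2 (0.05 log units; within the scatter), a 1.3-fold higher number from compound 1 to compound 3 (0.11 log units; within the scatter) and a 1.5-fold higher number from compound 2 to compound 3 (0.17 log units; within the scatter). Each exchanged a methyl, a chlorine or a bromine on that ring and none moved the number beyond the scatter. On that basis the bromine-to-chlorine exchange in compound 4 is expected to give no step beyond the scatter in this assay, and the expected shift is a 1.2-fold lower number from compound 3 to compound 4 (0.08 log units; within the scatter).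

Compound 4 is therefore estimated at 320000 nM, with a range from 200000 nM to 500000 nM.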

Compound 4, half-maximal cytotoxic concentration: 366000 nM
The estimate for compound 4 lay 1.1-fold (0.06 log units) below the measured number; the measured number falls inside the stated range.
By their numbers in this assay, from the lowest: compounds 2, 1, 4 and 3 (each within the scatter of the next).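

In this assay, the swap of bromine for chlorine on the aryl ester is a step of a 1.1-fold lower number from compound 3 to compound 4 (0.03 log units; within the scatter), and chloro in place of methyl on an aromatic carbon is a step of a 1.2-fold higher number from compound 1 to compound 4 (0.09 log units; within the scatter), so methyl, bromine and chlorine at this one place on the ring now give numbers that cannot be told apart. Going by these compounds alone, the comparison with compound 2 adds something the earlier compounds did not offer, two groups that carry the same atoms and differ only in where the chlorine sits: 2-chloro-6-(methoxycarbonyl)phenyl in place of 5-chloro-2-(methoxycarbonyl)phenyl is a step of a 1.4-fold higher number from compound 2 to compound 4 (0.14 log units; within the scatter), which also stays within the scatter. No measurement is available that could explain why these steps are so small.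

All four compounds keep the methyl ester and carry only a methyl, chlorine or bromine on this ring, so any statement about this aryl group is limited to those few groups. On these data alone, whether a carboxylic acid in place of the methyl ester, or an amine on the ring, would move the number beyond the scatter remains open.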